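Moving a methyl on the pyridine of a benzimidazole amide

The compounds below may be only part of what the source reports. "The series", "measured", "known", "first", "only" and "open" are said of these compounds alone.

Three compounds share one core. Compound 1 `Cc1ccccc1C(=O)n1c(-c2cn(-c3ccccc3)nc2-c2ccc(F)cc2)nc2ccccc21` gives 189000 nM in an ADME assay on HEK-293T cells (Homo sapiens) for cytotoxicity, read by MTT assay, with a stated time of 24 h; a lower number here means that less compound is tolerated, a higher number that more compound is tolerated. Compound 2 `Cc1ccc(-c2nn(-c3ccccc3)cc2-c2nc3ccccc3n2C(=O)c2ccc(Cl)cc2)cc1` gives 216000 nM, and compound 3 `Cc1ccc(-c2nn(-c3ccccc3)cc2-c2nc3ccccc3n2C(=O)c2ccc(C)nc2)cc1` gives 145000 nM. Compound 3 sits within the usual scatter of both others: the gap from compound 2 is a 1.5-fold lower number from compound 2 to compound 3 (0.17 log units; within the scatter), and compound 1 lies closer still.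

Compound 4 `Cc1ccc(-c2nn(-c3ccccc3)cc2-c2nc3ccccc3n2C(=O)c2cncc(C)c2)cc1` differs from compound 3 by 5-methylpyridin-3-yl in place of 6-methylpyridin-3-yl on a carbonyl carbon. Among the measured compounds shown here, the only measured change at the same spot, the step of a 1.5-fold lower number from compound 2 to compound 3 (0.17 log units; within the scatter), swapped a whole ring and stayed within the scatter; here only the methyl moves. Compound 4 is therefore expected to show a step of a 1.0-fold higher number from compound 3 to compound 4 (0.01 log units; within the scatter), no larger than the scatter. Compound 4 is estimated at 150000 nM, between 75000 nM and 300000 nM.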

Compound 4, half-maximal cytotoxic concentration: 155000 nM
Beside the measured number, compound 4's estimate is 1.0-fold (0.01 log units) below it, within the range that was stated.
By their numbers in this assay, from the lowest: compounds 3, 4, 1 and 2 (each within the scatter of the next).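

In this assay the shift of the methyl on the pyridine gives a 1.1-fold higher number from compound 3 to compound 4 (0.03 log units; within the scatter) and so, on this carbonyl carbon, the place of the methyl on the ring makes no readable difference. Putting 5-methylpyridin-3-yl in place of 4-chlorophenyl gives a 1.4-fold lower number from compound 2 to compound 4 (0.14 log units; within the scatter) and so this second pyridine, like the first, stays level with the chlorophenyl compound. Nothing available explains these numbers.

The compounds shown carry only aromatic rings on this carbonyl carbon. Going by these compounds, whether an amine, a carboxylic acid or a longer alkyl chain there would move the number beyond the scatter remains open.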